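Branching the ether side chain of an aminoquinoline

The compounds below may be only part of what the source reports. "The series", "measured", "known", "first", "only" and "open" are said of these compounds alone.

Measured compounds:
compound 1, `Nc1ccc2cccc(OCCC3CCCCC3)c2n1`, 808 nM
compound 2, `CC(C)Oc1cccc2ccc(N)nc12`, 437 nM

Of the compounds shown here, two sharing one core have been tested in an assay on cells with melanin-concentrating hormone receptor 1 (Homo sapiens) as the target, read by radioligand binding; on this read-out lower numbers stand for stronger inhibition and higher numbers for weaker inhibition. Compound 1 carries a longer side chain on the ether oxygen and gives 808 nM in this assay. Compound 2 carries a shorter branched chain and gives 437 nM in this assay, the lowest of the two numbers; its gap to compound 1 lies within the usual scatter, so the two compounds cannot be placed in order.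

Compound 3, `CC(C)C(C)Oc1cccc2ccc(N)nc12`, has not yet been measured in this assay. It differs from compound 2 in one place: isopropyl in place of methyl on a saturated chain carbon bound to an oxygen on an aromatic ring and a saturated chain carbon. For the measured compounds named here, no measured pair in this set shows the effect of such a change, and the two values at hand do not separate a longer chain from a shorter one beyond the scatter. The step from compound 2 to compound 3 is therefore expected to be small, a 1.1-fold lower number from compound 2 to compound 3 (0.04 log units; within the scatter), with no clear direction. On that basis compound 3 is estimated at 400 nM in this assay, within a range from 150 nM to 1200 nM.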

Compound 3, half-maximal inhibitory concentration: 199 nM
Compound 3: middle estimate off by 2.0-fold (0.30 log units), on the high side; the measured number falls inside the stated range.
By their numbers in this assay, from the lowest: compound 3; then compounds 2 and 1 (each within the scatter of the next).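

Putting isopropyl in place of methyl on a saturated chain carbon bound to an oxygen on an aromatic ring and a saturated chain carbon gives, in this assay, a 2.2-fold lower number from compound 2 to compound 3 (0.34 log units; beyond the scatter), a modest step but the first in this set that reads as a real change. For the compounds shown here, the two earlier compounds could not be placed in order, so this pair gives the only direct reading at this position: the side chain on the ether oxygen can go from isopropyl to 1,2-dimethylpropyl and the number still falls rather than rises. Nothing at hand explains why the number falls.

This single pair does not separate the effect of the added carbons from the effect of the branch itself, and it cannot show whether the trend would continue or reverse with a still larger group. A tert-butyl group, a cyclopentyl ring or a straight chain on the same carbon could begin to settle this, and an amine on the side chain would test a different kind of group at this position.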